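The compounds below may be only part of what the source reports. "The series", "measured", "known", "first", "only" and "open" are said of these compounds alone.

Compound 1, `COc1ccc(CN(C(=O)Nc2ccc(F)c(Cl)c2)n2cnnc2)cc1OC`, in a functional assay on MDA-MB-231 cells (Homo sapiens) for cytotoxicity, read by MTT assay, with a stated time of 48 h (a higher number here means a weaker inhibitor, a lower number a stronger inhibitor), gives 27900 nM. Compound 2, `COc1ccc(CN(C(=O)Nc2ccc(C#N)cc2)n2cnnc2)cc1OC`, reaches only a limit of the assay, > 50000 nM. Compound 3, `COc1ccc(CN(C(=O)Nc2ccc(C)cc2)n2cnnc2)cc1OC`, likewise sits at a limit of the assay, > 50000 nM.

Compound 3 thus stands at the limit of > 50000 nM in this assay, at which 2 of the 3 values shown sit, with no number of its own. Compound 4, `CCc1ccc(NC(=O)N(Cc2ccc(OC)c(OC)c2)n2cnnc2)cc1`, differs from compound 3 by methyl in place of hydrogen on a saturated chain carbon bound to an aromatic carbon. Among the compounds with values here, the steps that bear on this change of the group on the amide-type nitrogen are an at least 1.7-fold higher number from compound 1 to compound 3 (0.25 log units; that floor lies within the scatter) and an at least 1.7-fold higher number from compound 1 to compound 2 (0.25 log units; that floor lies within the scatter), while a step that the two limits leave unreadable from compound 2 to compound 3. None of them gives a readable direction for the ethyl change, so compound 4 is expected to remain near the limit. Compound 4 is estimated at 60000 nM, between 30000 nM and 150000 nM, so that a step that the limit leaves unreadable from compound 3 to compound 4 is expected to lie within the scatter.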

Compound 4, half-maximal inhibitory concentration: > 50000 nM
Compound 4: a limit, no number (the forecaster's own chance of this, stated with the estimate: 75%); the middle value is on the limit's open side.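

In this assay, the change from methyl to ethyl on the aryl group leaves compound 4 at the limit of the assay, with no number of its own, so this position has now taken a third group without giving a readable value: the limit of > 50000 nM in this assay, at which 3 of the 4 values shown sit.

Within the data shown here, the only readable step is an at least 1.7-fold higher number from compound 1 to compound 4 (0.25 log units; that floor lies within the scatter). The steps from compound 2 and compound 3 to compound 4 cannot be read.

Among the compounds shown, only compound 1 gives a number. Going by these compounds, it remains open whether a longer chain such as propyl, or an amine or a carboxylic acid, at this place would give one too.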